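Swapping the aryl group on the quinolone nitrogen

The source may hold more compounds than are shown below. What is called first, only, known or untested is meant among the compounds shown, and "the series" means these compounds.

Measured so far in a functional assay on A549 cells (Homo sapiens) for inhibition, read by MTT assay, with a stated time of 72 h; a higher number here means a weaker inhibitor, a lower number a stronger inhibitor:
- compound 1 `COc1ccc(-n2cc(C(=O)Nc3ccc(Oc4ccnc5[nH]ccc45)cc3)c(=O)c3ccccc32)cc1`: 4980 nM
- compound 2 `O=C(Nc1ccc(Oc2ccnc3[nH]ccc23)c(F)c1)c1cn(-c2ccc(Cl)cc2)c2ccccc2c1=O`: 320 nM
- compound 3 `O=C(Nc1ccc(Oc2ccnc3[nH]ccc23)c(F)c1)c1cn(-c2ccc(C(F)(F)F)cc2Cl)c2ccccc2c1=O`: 1620 nM

Among these three, compound 3 stands second highest, with compound 1 giving a higher number and compound 2 a lower one. For the measured compounds named here, the one step so far, a 5.1-fold higher number from compound 2 to compound 3 (0.70 log units; beyond the scatter), shows that the group on the aromatic nitrogen matters well beyond the scatter.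

Compound 4 `COc1ccc(-n2cc(C(=O)Nc3ccc(Oc4ccnc5[nH]ccc45)c(F)c3)c(=O)c3ccccc32)cc1` makes the change (4-methoxyphenyl in place of 2-chloro-4-(trifluoromethyl)phenyl on an aromatic nitrogen). Going by the values given here, no measured step covers this exact exchange. The closest guide is compound 1, which also bears 4-methoxyphenyl on the aromatic nitrogen and gives 4980 nM in this assay, a weaker result than compound 3. That suggests the 4-methoxyphenyl group tends toward higher numbers here, though compound 1 and compound 4 also differ elsewhere, so the pull is uncertain.

For compound 4 the expected step is a 1.9-fold higher number from compound 3 to compound 4 (0.27 log units; within the scatter), toward a weaker inhibitor but likely inside the scatter. Compound 4 is therefore estimated at 3000 nM, with a range from 1000 nM to 9000 nM.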

Compound 4, half-maximal inhibitory concentration: 4150 nM
Compound 4: the middle estimate sits 1.4-fold (0.14 log units) below what was measured, and the stated range covers the measured number.
By their numbers in this assay, from the lowest: compound 2; then compound 3; then compounds 4 and 1 (each within the scatter of the next).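

In this assay, the 4-methoxyphenyl group on the aromatic nitrogen gives a higher number than the 2-chloro-4-(trifluoromethyl)phenyl group, with a 2.6-fold higher number from compound 3 to compound 4 (0.41 log units; beyond the scatter). Methoxy in place of chloro on that aryl ring, the only change between the two compounds, has a large effect, with a 13-fold higher number from compound 2 to compound 4 (1.11 log units; beyond the scatter), so this single group on the ring strongly shapes the result. Fluoro in place of hydrogen on the shared core, by contrast, gives a 1.2-fold lower number from compound 1 to compound 4 (0.08 log units; within the scatter), so with 4-methoxyphenyl in place this change cannot be told apart from the scatter.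

No supporting measurement explains why methoxy and chloro differ so much here. From the compounds shown here alone, it remains open how a dimethylamino group or a plain methyl group on that aryl ring would compare, and whether fluoro would matter alongside 4-chlorophenyl.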